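This account rests on a few compounds, and the source may have more. Where it says the series, first, only, none or still open, it means among the compounds named here.

Three compounds built on a shared core have been examined so far, and a fourth awaits testing. Compound 1 `CCCCCC(=O)Nc1cc2nc(C3CCCCC3)[nH]c2cc1N(CC)CC` differs from the others in its amide portion; compound 2 `CCN(CC)c1cc2[nH]c(C3CCCCC3)nc2cc1NC(=O)c1ccc(F)cc1` carries a fluoro on an aromatic carbon of its amide ring; compound 3 `CCN(CC)c1cc2[nH]c(C3CCCCC3)nc2cc1NC(=O)c1ccc(OC(F)F)cc1` carries a 4-(difluoromethoxy)phenyl amide. In an ADME assay on Vero cells (Chlorocebus sabaeus) for cytotoxicity, read by resazurin assay, with a stated time of 3 days (a higher number here means a weaker inhibitor, a lower number a stronger inhibitor), compound 1 gives "not determined" (no result reported). In this assay compound 2 gives > 100 ug/mL, which is a limit of the assay rather than a number. Compound 3 likewise gives > 100 ug/mL, again a limit and not a number. The step that the two limits leave unreadable from compound 2 to compound 3 therefore cannot be sized, and the limit of > 100 ug/mL in this assay, at which 2 of the 3 values shown sit, describes where both of these values sit. So compound 3 stands at the limit, alongside compound 2, while compound 1 offers no figure at all.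

Compound 4 `CCN(CC)c1cc2[nH]c(C3CCCCC3)nc2cc1NC(=O)c1ccc(OC(F)(F)F)cc1` differs from compound 3 by fluoro in place of hydrogen on a saturated chain carbon bound to two fluorine atoms and an oxygen on an aromatic ring. For the measured compounds named here, the only measured step bearing on this change, a step that the two limits leave unreadable from compound 2 to compound 3, is itself unreadable, so no direction can be drawn from it; what the two fluorinated amides show is simply that both sit at the limit. Compound 4 is therefore expected to give 100 ug/mL, with a range from 50 ug/mL to 200 ug/mL, most likely reported as a limit once more. The step of a number no higher from compound 3 to compound 4 (the limit leaves the size open) is accordingly expected to be none beyond the scatter.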

Compound 4, half-maximal inhibitory concentration: > 100 ug/mL
Compound 4 gave a limit, no number (the forecaster's own chance of this, stated with the estimate: 80%); the middle value sits exactly at the limit.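

For the compounds shown here, compound 2, compound 3 and compound 4 each stand at a limit of this assay rather than at a number, so no step among them can be read: the limit of > 100 ug/mL in this assay, at which 3 of the 4 values shown sit. The compounds shown leave open where the true values of these three lie, and whether fluoro, difluoromethoxy and trifluoromethoxy differ at all here.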